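Swapping the Aryl Group on the Ring Nitrogen

This account rests on a few compounds, and the source may have more. Where it says the series, first, only, none or still open, it means among the compounds named here.

Of the compounds shown here, two with a shared core have been tested in a functional assay on PC-3 cells (Homo sapiens) for antiproliferative activity, read by MTT assay, with a stated time of 48 h; a higher number here means a weaker inhibitor, a lower number a stronger inhibitor. Compound 1 `COc1cc(/C=C/C(C)=O)ccc1OCc1cn(-c2ccc(/N=N/c3ccccc3)cc2)nn1` gives 42100 nM. Compound 2 `COc1cc(/C=C/C(C)=O)ccc1OCc1cn(-c2ccccc2OC)nn1` gives 2050 nM, the lower of the two numbers and the stronger inhibitor, a gap beyond the usual scatter. Compound 3 `COc1cc(/C=C/C(C)=O)ccc1OCc1cn(-c2ccc(C=O)cc2)nn1` arises from compound 2 through one change: 4-formylphenyl in place of 2-methoxyphenyl on an aromatic nitrogen. For the measured compounds named here, no measured pair shows this exact change, so its effect remains open. The step expected here is a 2.4-fold higher number from compound 2 to compound 3 (0.39 log units; beyond the scatter), a modest move toward a weaker inhibitor. In this assay compound 3 is estimated at 5000 nM, with a range from 1500 nM to 20000 nM.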

Compound 3, half-maximal inhibitory concentration: 80700 nM
Estimate against measurement, compound 3: 16-fold (1.21 log units) below; measured number outside the range, above it.
By their numbers in this assay, from the lowest: compound 2; then compounds 1 and 3 (each within the scatter of the next).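

On this aromatic nitrogen, the identity of the aryl group matters a great deal in this assay: two groups with the same heavy-atom count, 2-methoxyphenyl and 4-formylphenyl, are separated by a 39-fold higher number from compound 2 to compound 3 (1.60 log units; beyond the scatter). Replacing the phenylazo group on the aromatic carbon with formyl gives a 1.9-fold higher number from compound 1 to compound 3 (0.28 log units; within the scatter), so these two groups cannot be told apart here. Nothing available explains the large step. From the compounds shown here alone, whether it comes from the methoxy group itself or from where it sits remains open. A 4-methoxyphenyl or plain phenyl group on that nitrogen would help separate these possibilities.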